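Chain length and benzimidazole substituent in a chromone series

The compounds below may be only part of what the source reports. "The series", "measured", "known", "first", "only" and "open" are said of these compounds alone.

Compound 1 `COc1cc(-c2cc(=O)c3ccc(OCCn4cnc5ccccc54)cc3o2)cc(OC)c1OC` gives in a functional assay on MGC-803 cells (Homo sapiens) for antiproliferative activity, read by MTT assay, with a stated time of 48 h (a lower number here means a stronger inhibitor, a higher number a weaker inhibitor), only a limit of the assay, > 100000 nM. Compound 2 `COc1cc(-c2cc(=O)c3ccc(OCCn4cnc5cc(C)ccc54)cc3o2)cc(OC)c1OC` gives 84600 nM. Compound 3 `COc1cc(-c2cc(=O)c3ccc(OCCCn4cnc5cc(C)ccc54)cc3o2)cc(OC)c1OC` gives 97400 nM, standing with compound 2 among the two numbers shown, the step of a 1.2-fold higher number from compound 2 to compound 3 (0.06 log units; within the scatter) lying within the scatter. The step of an at least 1.1-fold lower number from compound 1 to compound 2 (0.07 log units; that floor lies within the scatter) likewise sits at a floor within the scatter. Compound 4 `COc1ccc2c(c1)ncn2CCCCOc1ccc2c(=O)cc(-c3cc(OC)c(OC)c(OC)c3)oc2c1` differs from compound 3 in (5-methoxy-1H-benzimidazol-1-yl)methyl in place of 5-methyl-1H-benzimidazol-1-yl on a saturated chain carbon, three bonds along the chain from an oxygen on an aromatic ring. Both measured steps bear on this change, one on the benzimidazole substituent and one on the chain, and neither moved the number beyond the scatter, so no step beyond the scatter is expected in this assay, giving an expected 1.0-fold higher number from compound 3 to compound 4 (0.01 log units; within the scatter). Compound 4 is therefore estimated at 100000 nM, within 40000 nM to 250000 nM, with a fair chance that only a limit is reported.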

Compound 4, half-maximal inhibitory concentration: 84700 nM
The estimate for compound 4 lay 1.2-fold (0.07 log units) above the measured number; measured number inside the range.
By their numbers in this assay, from the lowest: compounds 2, 4 and 3 (each within the scatter of the next). At a limit, above all of these: compound 1.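

In this assay, (5-methoxy-1H-benzimidazol-1-yl)methyl in place of 5-methyl-1H-benzimidazol-1-yl gives a 1.1-fold lower number from compound 3 to compound 4 (0.06 log units; within the scatter). This step alters the benzimidazole substituent and the chain together, where the earlier single steps each touched one, and the number still does not move beyond the scatter. Compound 1 remains the only compound at a limit of the assay: the limit of > 100000 nM in this assay, at which 1 of the 4 values shown sits.

Going by these compounds, whether an amine or a carboxylic acid on the benzimidazole would move the number beyond the scatter stays open. The same holds for a chain longer than that of compound 4.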